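The compounds below may be only part of what the source reports. "The series", "measured", "known", "first", "only" and "open" are said of these compounds alone.

Compound 1, `COc1nc(N)nc2c1c(-c1ccccc1)cn2[C@@H]1O[C@H](CO)[C@@H](O)[C@H]1O`, gives in a functional assay on HCT-116 cells (Homo sapiens), read by MTT assay, with a stated time of 72 h (a lower number here means a stronger inhibitor, a higher number a weaker inhibitor), only a limit of the assay, > 20000 nM.
Compound 2, `COc1ncnc2c1c(-c1ccccc1)cn2[C@@H]1O[C@H](CO)[C@@H](O)[C@H]1O`, gives in this assay likewise only a limit, > 20000 nM.
Compound 3, `CNc1ncnc2c1c(-c1ccccc1)cn2[C@@H]1O[C@H](CO)[C@@H](O)[C@H]1O`, gives in this assay also only a limit, > 20000 nM.

Compound 2 therefore stands at the limit of this assay, with no number of its own, and its two neighbours stand at the same limit, as the limit of > 20000 nM in this assay, at which 3 of the 3 values shown sit, records. The step from compound 1 to compound 2, hydrogen in place of amino on an aromatic carbon, comes out as a step that the two limits leave unreadable from compound 1 to compound 2. The step from compound 2 to compound 3, methylamino in place of methoxy on an aromatic carbon, comes out as a step that the two limits leave unreadable from compound 2 to compound 3. Neither step has a readable size, so the measured compounds give no measure of how far any change moves this assay.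

Compound 4, `COc1ncnc2c1c(-c1ccco1)cn2[C@@H]1O[C@H](CO)[C@@H](O)[C@H]1O`, differs from compound 2 as follows: furan-2-yl in place of phenyl on an aromatic carbon. Among the compounds with values here, no measured step concerns the furan-2-yl or the phenyl, so nothing here points to a direction. With every measured value sitting at the limit, the plain expectation is that compound 4 also sits at or near it. The expected step is a step that the limit leaves unreadable from compound 2 to compound 4. Compound 4 is thus estimated at 30000 nM, with a range from 8000 nM to 100000 nM, and most probably reported only as a limit again.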

Compound 4, half-maximal inhibitory concentration: 40 nM
Beside the measured number, compound 4's estimate is 750-fold (2.88 log units) above it; measured number outside the range, below it.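

In this assay, within the data shown here, furan-2-yl in place of phenyl on this aromatic carbon gives an at least 500-fold lower number from compound 2 to compound 4 (2.69 log units; beyond the scatter), the first change with a size that can be read, since the earlier steps cannot be read. The amino, methoxy and methylamino changes left every compound with phenyl at the assay limit, so those compounds could not show whether the group at this position mattered, whereas this single exchange shows that it can decide between no measurable effect on the cells and a strong one. The size of the step is itself only a bound, as compound 2 has no number of its own, and the limit it shares with its neighbours marks the end of what the assay reports: the limit of > 20000 nM in this assay, at which 3 of the 4 values shown sit.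

The exchange changes two things at once, replacing a six-membered carbon ring with a five-membered ring that carries an oxygen, and the compounds shown do not separate these, which a thiophen-2-yl or a furan-3-yl group at the same position could begin to do. As far as these compounds go, it also remains open whether furan-2-yl acts in the same way when the methoxy of compound 4 is replaced by an amine such as methylamino.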